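Cyclic Ester-Bearing Amide Variant of a Cholesterol Transporter Ligand

A few compounds are considered here, and "the series" means these few. Any claim that something is new, unique, unknown or untested is made for them only; others in the source may bear on it.

Measured so far:
compound 1, `COC(=O)CCCNC(=O)CN1CN(c2ccccc2)C2(CCN(C(=O)c3ccc(C4CCCCC4)cc3)CC2)C1=O`: 2500 nM
compound 3, `CC1CCCN(C(=O)CN2CN(c3ccccc3)C3(CCN(C(=O)c4ccc(C(C)(C)C)cc4)CC3)C2=O)C1`: 12000 nM

In an assay on HEK293 cells for displacement of a labelled ligand from NPC1-like intracellular cholesterol transporter 1 (Homo sapiens) (on this read-out higher numbers stand for weaker inhibition and lower numbers for stronger inhibition), compound 1 gives 2500 nM, the lower of the two numbers available. Among the measured compounds shown here, compound 3, `CC1CCCN(C(=O)CN2CN(c3ccccc3)C3(CCN(C(=O)c4ccc(C(C)(C)C)cc4)CC3)C2=O)C1`, gives 12000 nM in this assay, a higher number than compound 1 by a gap that lies beyond the usual scatter; no step between these two is defined, since they differ in more than one place. Compound 2, `COC(=O)CCCNC(=O)CN1CN(c2ccccc2)C2(CCN(C(=O)c3ccc(C(C)(C)C)cc3)CC2)C1=O`, belongs to the same series, but in this assay compound 2 stands as "not determined" (no result reported), so no number is available for it.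

Compound 4, `CCOC(=O)C1CCCN(C(=O)CN2CN(c3ccccc3)C3(CCN(C(=O)c4ccc(C5CCCCC5)cc4)CC3)C2=O)C1`, differs from compound 1 in one place: 3-(ethoxycarbonyl)piperidin-1-yl in place of (3-(methoxycarbonyl)propyl)amino on a carbonyl carbon. The amide hydrogen of compound 1 is thus lost and the chain is closed into a ring bearing an ethyl ester. For the measured compounds named here, with no single-change step recorded, the expected step in this assay rests on compound 3, whose ring-closed amide gives 12000 nM, a weaker result than compound 1. The estimate for compound 4 is therefore a step toward a higher number, a 1.8-fold higher number from compound 1 to compound 4 (0.26 log units; within the scatter), though the aryl group of compound 3 also differs, so the direction is uncertain. Compound 4 is expected to give about 4500 nM, within 1500 nM to 14000 nM.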

Compound 4, half-maximal inhibitory concentration: 4200 nM
Compound 4: the middle estimate sits 1.1-fold (0.03 log units) above what was measured, within the range that was stated.
By their numbers in this assay, from the lowest: compounds 1 and 4 (each within the scatter of the next); then compound 3.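

In this assay, among the compounds shown here, this is the first comparison that changes one place only, with the cyclohexyl group and the rest of the core of compound 1 held fixed, and it gives a 1.7-fold higher number from compound 1 to compound 4 (0.23 log units; within the scatter). At this carbonyl carbon, therefore, the open (3-(methoxycarbonyl)propyl)amino chain with its amide hydrogen and the 3-(ethoxycarbonyl)piperidin-1-yl ring without one cannot be told apart on this read-out, even though the entering group is larger and carries an ethyl rather than a methyl ester. For the compounds shown here, nothing measured here accounts for this result, and the single exchange combines the ring, the lost hydrogen and the changed ester, so their separate contributions cannot be read.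

The compounds shown leave open whether the ester is needed at all, as neither a carboxylic acid nor an unsubstituted piperidine stands at this place in a compound otherwise matching compound 4. They also leave open how the cyclohexyl and tert-butyl groups compare, since compound 2 has no number and compound 3 differs from compound 1 and compound 4 in more than one place.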